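The source may hold more compounds than are shown below. What is called first, only, known or untested is meant among the compounds shown, and "the series" means these compounds.

In a functional assay on PC-3 cells (Homo sapiens) for inhibition, read by MTT assay, with a stated time of 72 h (a lower number here means a stronger inhibitor, a higher number a weaker inhibitor), two compounds on a shared core have been measured. Compound 1 `CN1CCN(c2cc(C(F)(F)F)nc(SCc3ccc(C(F)(F)F)cc3)n2)CC1` gives 34700 nM. Compound 2 `Cc1nnc(Sc2cc(C(F)(F)F)nc(SCc3ccc(C(F)(F)F)cc3)n2)s1` gives > 50000 nM, which is a limit of the assay and not a number, so its position is known only as a limit. Compound 3 `FC(F)(F)c1ccc(CSc2nc(SC3=NCCS3)cc(C(F)(F)F)n2)cc1` differs from compound 2 in one place, on a sulfur whose other neighbour is an aromatic carbon: a group of 5 heavy atoms (3 carbon, 1 nitrogen, 1 sulfur; one five-membered non-aromatic ring with 2 hetero atoms) in place of a group of 6 heavy atoms (3 carbon, 2 nitrogen, 1 sulfur; one five-membered aromatic ring with 3 hetero atoms), on a sulfur. The 5-methyl-1,3,4-thiadiazol-2-yl group leaves, and a five-membered non-aromatic ring enters. Among the compounds with values here, no measured step changes the group on that sulfur. Within the data shown here, the only step that bears on the change, and then only loosely, is an at least 1.4-fold higher number from compound 1 to compound 2 (0.15 log units; that floor lies within the scatter), which introduced the (5-methyl-1,3,4-thiadiazol-2-yl)sulfanyl group in place of 4-methylpiperazin-1-yl on an aromatic carbon. Among the measured compounds shown here, with only that step to go on, no change beyond the scatter is expected in this assay, and no direction can be favoured. The expected step is an at least 1.1-fold lower number from compound 2 to compound 3 (0.04 log units; that floor lies within the scatter). The estimate for compound 3 is 45000 nM, with an expected range from 20000 nM to 90000 nM.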

Compound 3, half-maximal inhibitory concentration: 40600 nM
Compound 3: middle estimate off by 1.1-fold (0.04 log units), on the high side; low and high end bracket the measured number.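

Within the data shown here, what compound 3 adds is a first actual number for a group on a sulfur whose other neighbour is an aromatic carbon: in this assay, the five-membered non-aromatic ring in place of the 5-methyl-1,3,4-thiadiazol-2-yl group gives an at least 1.2-fold lower number from compound 2 to compound 3 (0.09 log units; that floor lies within the scatter). Compound 2 is held by a limit of the assay and not a number, so this step is known only as a floor: the limit of > 50000 nM in this assay, at which 1 of the 3 values shown sits. The wider change on the aromatic carbon, the same ring attached through sulfur in place of 4-methylpiperazin-1-yl, gives a 1.2-fold higher number from compound 1 to compound 3 (0.07 log units; within the scatter), so in this assay the two values cannot be told apart, and a change of ring, of ring size and of the atom joining the ring to the shared core leaves no mark beyond the scatter.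

On these data alone, whether an amine or a carboxylic acid on that sulfur, or a longer chain in place of the ring, would move the number in this assay beyond the scatter stays open. The compounds shown also leave open what a change elsewhere on the shared core would do, as all of them differ only in this one group.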